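Swapping Phenyl for Pyridin-4-yl on Compound 2

The source may hold more compounds than are shown below. What is called first, only, known or untested is meant among the compounds shown, and "the series" means these compounds.

Among the measured compounds shown here, in a functional assay on cells (Homo sapiens) for cytotoxicity, read by MTT assay, with a stated time of 48 h (a lower number here means a stronger inhibitor, a higher number a weaker inhibitor), compound 2 (`CN(C)CCN1CCN(C2=Nc3ccccc3C(CC(=O)NCc3ccccc3)N2c2ccc(-c3ccccc3)cc2)CC1`) gives 2390 nM as the only true number among the three compounds measured so far. Compound 1 (`CN(C)CCCCCN(C)C1=Nc2ccccc2C(CC(=O)NCc2ccccc2)N1c1ccc(-c2ccccn2)cc1`) reads > 5000 nM and this is a limit. Compound 3 (`CN(C)CCN1CCN(C2=Nc3ccccc3C(CC(=O)NCc3ccccc3)N2c2ccc(-c3ccccn3)cc2)CC1`) reads > 5000 nM and this too is a limit.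

Compound 4 (`CN(C)CCN1CCN(C2=Nc3ccccc3C(CC(=O)NCc3ccncc3)N2c2ccc(-c3ccccc3)cc2)CC1`) differs from compound 2 in one place (pyridin-4-yl in place of phenyl on a saturated chain carbon bound to an amide-type nitrogen), with pyridin-4-yl in place of phenyl on a saturated chain carbon bound to an amide-type nitrogen. The closest measured parallel is an at least 2.0-fold higher number from compound 2 to compound 3 (0.32 log units; beyond the scatter) when pyridin-2-yl replaces phenyl on an aromatic carbon. That swap sits elsewhere in the molecule and ends on a limit, so it is only a loose guide. On that evidence the estimated change is a 1.7-fold higher number from compound 2 to compound 4 (0.22 log units; within the scatter) in this assay and it is expected to point towards a weaker inhibitor. For compound 4 the estimate is 4000 nM with an expected range from 1800 nM to 9000 nM in this measurement, and a reading that is only a limit remains possible.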

Compound 4, half-maximal inhibitory concentration: > 5000 nM
Compound 4 ended at the assay's limit; the forecaster's own chance of this, stated with the estimate: 40%; middle value at least 1.2-fold (0.09 log units) from the limit.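

In this assay, putting pyridin-4-yl in place of phenyl on a saturated chain carbon bound to an amide-type nitrogen gives an at least 2.0-fold higher number from compound 2 to compound 4 (0.32 log units; beyond the scatter). The earlier compounds showed such a swap only on an aromatic carbon, with an at least 2.0-fold higher number from compound 2 to compound 3 (0.32 log units; beyond the scatter), so among these compounds a carbon-only ring exchanged for a ring holding one nitrogen moves the number the same way at both places. Compound 4 reads > 5000 nM, and this is a limit.

Still open, on these data alone, is whether pyridin-3-yl, or a phenyl ring carrying an amine or a carboxylic acid, or a longer chain leading from the amide nitrogen to the ring, would give a true number at this place. How far compound 4 lies past its reading also stays hidden, and the shown series offers little room to tell such compounds apart: the limit of > 5000 nM in this assay, at which 3 of the 4 values shown sit.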